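The compounds below may be only part of what the source reports. "The series", "measured", "known", "first", "only" and "open" are said of these compounds alone.

Measured so far:
Compound 1, `CCOC(=O)c1[nH]c2cc(Cl)ccc2c1/C=N/NC(=O)Cc1ccccc1`, in an assay for inhibition of Polyunsaturated fatty acid lipoxygenase ALOX15 (Homo sapiens), with a stated time of 8 min (on this read-out lower numbers stand for stronger inhibition and higher numbers for weaker inhibition), gives > 10000 nM, which is a limit of the assay.
Compound 2, `CCOC(=O)c1[nH]c2cc(Cl)ccc2c1/C=N/NC(=O)CCC(C)C`, in this assay gives > 10000 nM, also a limit.
Compound 3, `CCCCC(=O)N/N=C/c1c(C(=O)OCC)[nH]c2cc(Cl)ccc12`, in this assay gives > 10000 nM, again a limit.

Compound 3 thus stands only at the limit (the limit of > 10000 nM in this assay, at which 3 of the 3 values shown sit). Compound 1 and compound 2 sit at the same limit. The steps a step that the two limits leave unreadable from compound 1 to compound 2, a step that the two limits leave unreadable from compound 1 to compound 3 and a step that the two limits leave unreadable from compound 2 to compound 3 are all left unreadable by that limit, so no size for any change at this position can be taken from the series.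

Compound 4, `CCOC(=O)c1[nH]c2cc(Cl)ccc2c1/C=N/NC(=O)CC1CCCC1`, differs from compound 3 by cyclopentyl in place of propyl on a saturated chain carbon bound to a carbonyl carbon. With three limits and no readable step, compound 4 is expected to remain at the limit as well. Compound 4 is estimated at 15000 nM, in the range 5000 nM to 50000 nM. The step that the limit leaves unreadable from compound 3 to compound 4 is expected to be none beyond the scatter.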

Compound 4, half-maximal inhibitory concentration: > 10000 nM
Compound 4 ended at the assay's limit (the forecaster's own chance of this, stated with the estimate: 85%); the middle value lies beyond the limit too.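

The steps to compound 4 from compound 1, compound 2 and compound 3 cannot be read: the limit of > 10000 nM in this assay, at which 4 of the 4 values shown sit.

The compounds shown leave open whether any group at this position on the shared core gives a measurable inhibition value.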